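A few compounds are considered here, and "the series" means these few. Any claim that something is new, unique, unknown or untested is made for them only; others in the source may bear on it.

Measured in a functional assay on RS4-11 cells (Homo sapiens) for inhibition, read by CCK-8 assay, with a stated time of 48 h; on this read-out higher numbers stand for weaker inhibition and lower numbers for stronger inhibition:
- Compound 1 `O=S(=O)(NCCNC(=S)Nc1cccc(Cl)c1)c1ccc(-c2ccccc2OCc2cccc(O)c2)s1`: 5800 nM
- Compound 2 `Cc1cc(C)cc(NC(=O)NCCNS(=O)(=O)c2ccc(-c3ccccc3OCc3cccc(O)c3)s2)c1`: 5800 nM
- Compound 3 `COc1ccc(NC(=O)NCCNS(=O)(=O)c2ccc(-c3ccccc3Oc3ccc([N+](=O)[O-])cc3)s2)cc1`: > 50000 nM

The value of compound 3 is a limit of the assay and not a number, so compound 3 stands at the limit of > 50000 nM in this assay, at which 1 of the 3 values shown sits.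

Compound 4 `COc1ccc(NC(=O)NCCNS(=O)(=O)c2ccc(-c3ccccc3OCc3cccc(O)c3)s2)cc1` differs from compound 3 in one place: 3-hydroxybenzyl in place of 4-nitrophenyl on an oxygen on an aromatic ring. In words, 3-hydroxybenzyl sits in place of 4-nitrophenyl on an oxygen on an aromatic ring.

Going by the values given here, no measured step covers this swap. Among the compounds with values here, the only measured step, no change at the digits printed from compound 1 to compound 2 (within the scatter), lies elsewhere in the molecule and stays within the scatter, so changes at that other place may matter little. Compound 1 and compound 2 both carry the entering 3-hydroxybenzyl group on that oxygen, and the expectation rests on compound 1 at 5800 nM and compound 2 at 5800 nM.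

A large step toward stronger inhibition in this assay is therefore expected: an at least 8.3-fold lower number from compound 3 to compound 4 (0.92 log units; beyond the scatter). For compound 4 the estimated value is 6000 nM, with an expected range from 2500 nM to 15000 nM.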

Compound 4, half-maximal inhibitory concentration: 9400 nM
Compound 4: the middle estimate sits 1.6-fold (0.19 log units) below what was measured, and the stated range covers the measured number.
By their numbers in this assay, from the lowest: compounds 1, 2 and 4 (each within the scatter of the next). At a limit, above all of these: compound 3.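

Compound 3 in this assay gives a limit of the assay and not a number: the limit of > 50000 nM in this assay, at which 1 of the 4 values shown sits.

Even so, the swap to 3-hydroxybenzyl in place of 4-nitrophenyl on this oxygen can be read as a real gain, an at least 5.3-fold lower number from compound 3 to compound 4 (0.72 log units; beyond the scatter), and its full size stays unknown. With 3-hydroxybenzyl in place, the group at the other end of the molecule shifts the result only within the scatter, both for 4-methoxyphenyl in place of 3,5-dimethylphenyl, a 1.6-fold higher number from compound 2 to compound 4 (0.21 log units; within the scatter), and for the change on the amine nitrogen, a 1.6-fold higher number from compound 1 to compound 4 (0.21 log units; within the scatter).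

Still open, from the compounds shown here alone, is whether the gain follows the hydroxyl or the benzyl link, a question that plain benzyl or 3-methoxybenzyl on this oxygen could separate. A 3-aminobenzyl group there would test whether another group can stand in for the hydroxyl.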